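This account rests on a few compounds, and the source may have more. Where it says the series, first, only, none or still open, it means among the compounds named here.

In an ADME assay on J774.A1 cells (Mus musculus) for cytotoxicity, read by MTT assay, with a stated time of 48 h (a higher number here means that more compound is tolerated, a lower number that less compound is tolerated), compound 1 `COC(=O)c1c([N+](=O)[O-])noc1-c1ccc(Cl)cc1Cl` gives 19700 nM, and compound 2 `O=C(Nc1ccccc1)c1c([N+](=O)[O-])noc1-c1ccc(Cl)cc1` gives 89300 nM. Compound 2 holds the higher of the two numbers, and the gap to compound 1 lies beyond the usual scatter. Compound 3 `O=C(Nc1ccccc1)c1c([N+](=O)[O-])noc1-c1ccc(Cl)cc1Cl` departs from compound 2 at one place: chloro in place of hydrogen on an aromatic carbon. This puts chloro in place of hydrogen on an aromatic carbon, ortho to a large group and meta to a chloro group, turning 4-chlorophenyl into 2,4-dichlorophenyl. For the measured compounds named here, no measured pair isolates this change. Compound 1 also carries 2,4-dichlorophenyl and stands at 19700 nM, but it differs from compound 2 elsewhere too, so it is only a weak guide. In this assay a modest move to a lower number is expected, near the edge of the scatter. The expected change is a 2.0-fold lower number from compound 2 to compound 3 (0.30 log units; within the scatter). For compound 3 the estimated value is 45000 nM, with a range of 18000 nM to 100000 nM.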

Compound 3, half-maximal cytotoxic concentration: 67300 nM
For compound 3 the middle estimate is 1.5-fold (0.17 log units) below the measured one; the measured number falls inside the stated range.
By their numbers in this assay, from the lowest: compound 1; then compounds 3 and 2 (each within the scatter of the next).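

In this assay chloro in place of hydrogen on an aromatic carbon, ortho to a large group and meta to a chloro group, gives a 1.3-fold lower number from compound 2 to compound 3 (0.12 log units; within the scatter) and so does not separate 4-chlorophenyl from 2,4-dichlorophenyl while the anilino carbonyl is present. For the compounds shown here, with 2,4-dichlorophenyl held constant, anilino in place of methoxy on a carbonyl carbon gives a 3.4-fold higher number from compound 1 to compound 3 (0.53 log units; beyond the scatter) and is the only step here that lies beyond the scatter. No supporting data bear on the size of either step.

As far as these compounds go, whether the anilino step keeps its size with 4-chlorophenyl remains open. Also open, from the compounds shown here alone, is how a carboxylic acid or a primary amide on that carbonyl carbon, or a fluoro or methoxy group in place of the new chloro, would read in this assay.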